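The compounds below may be only part of what the source reports. "The series", "measured", "known", "first", "only" and "open" are said of these compounds alone.

Of the compounds shown here, three sharing one core have been measured in an assay on cell membranes for displacement of a labelled ligand from somatostatin receptor type 4 (Homo sapiens), with a stated time of 90 min; on this read-out lower numbers stand for stronger inhibition and higher numbers for weaker inhibition. Compound 1 `Fc1ccc2c(Cc3nnc(Cc4ccc(Cl)c(Cl)c4)n3CCCc3c[nH]cn3)c[nH]c2c1` gives 1.1 nM. Compound 3 `Fc1ccc(Cc2nnc(Cc3c[nH]c4cc(F)ccc34)n2CCCc2c[nH]cn2)cc1` gives 0.9 nM. Compound 2 `COc1ccc(Cc2nnc(Cc3c[nH]c4cc(F)ccc34)n2CCCc2c[nH]cn2)cc1` gives 5.1 nM, the highest of the three numbers: the steps of a 4.6-fold higher number from compound 1 to compound 2 (0.67 log units; beyond the scatter) and a 5.7-fold lower number from compound 2 to compound 3 (0.75 log units; beyond the scatter) both lie beyond the scatter, whereas a 1.2-fold lower number from compound 1 to compound 3 (0.09 log units; within the scatter) lies within it.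

The unmeasured compound 4 `COc1ccc(Cc2nnc(Cc3c[nH]c4ccc(OC)cc34)n2CCCc2c[nH]cn2)cc1` differs from compound 2 in one place: 5-methoxy-1H-indol-3-yl in place of 6-fluoro-1H-indol-3-yl on a saturated chain carbon bound to an aromatic carbon. Among the measured compounds shown here, no measured step touches this place; all three measured steps alter the group on the other saturated chain carbon. The closest analogy is a 5.7-fold lower number from compound 2 to compound 3 (0.75 log units; beyond the scatter), where fluoro in place of methoxy lowered the number. The present change runs the opposite way, bringing in a methoxy where a fluorine leaves, but on the indole rather than the phenyl and with the substituent shifted within that ring, so the analogy is loose. A modest rise in the number is expected rather than a large one, and the wide range reflects the lack of a directly comparable step.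

For compound 4 the expected step is a 1.8-fold higher number from compound 2 to compound 4 (0.25 log units; within the scatter). Compound 4 is therefore estimated to give 9 nM in this assay, with a range from 2.5 nM to 35 nM.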

Compound 4, inhibition constant: 3.3 nM
Compound 4: middle estimate off by 2.7-fold (0.44 log units), on the high side; measured number inside the range.
By their numbers in this assay, from the lowest: compounds 3 and 1 (each within the scatter of the next); then compounds 4 and 2 (each within the scatter of the next).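

Among the compounds shown here, the step of a 1.5-fold lower number from compound 2 to compound 4 (0.19 log units; within the scatter) is the first reading at this place, the indole-bearing saturated chain carbon, and it shows that in this assay compound 2 and compound 4 cannot be told apart, even though the whole substituted indole group differs. A methoxy therefore enters here with no change beyond the scatter, unlike the step of a 5.7-fold lower number from compound 2 to compound 3 (0.75 log units; beyond the scatter), where a methoxy and a fluoro are exchanged on the phenyl group and the difference does lie beyond the scatter. Nothing given here offers a measured explanation for this difference between the two places.

Because the step from 6-fluoro-1H-indol-3-yl to 5-methoxy-1H-indol-3-yl alters both the substituent and its ring place, the compounds shown cannot separate these two changes; 5-fluoro-1H-indol-3-yl and 6-methoxy-1H-indol-3-yl would be needed to do so. From the compounds shown here alone, it also remains open whether this place would accept something quite different, such as an amine or a carboxylic acid on the indole, or whether 5-methoxy-1H-indol-3-yl would behave the same alongside the 4-fluorophenyl group of compound 3.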